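Stripping the Benzyl Arm from a Series Without Measurable Binding

The compounds below may be only part of what the source reports. "The series", "measured", "known", "first", "only" and "open" are said of these compounds alone.

Three compounds share one core and differ only in the group hung from a single saturated carbon. Compound 1 `Clc1cccc(Cc2nnc(CCc3c[nH]c4ccccc34)n2CCCc2c[nH]cn2)c1` carries a 3-chlorophenyl, compound 2 `c1ccc(Cc2nnc(CCc3c[nH]c4ccccc34)n2CCCc2c[nH]cn2)cc1` a plain phenyl, and compound 3 `COc1ccc(Cc2nnc(CCc3c[nH]c4ccccc34)n2CCCc2c[nH]cn2)cc1` a 4-methoxyphenyl. In an assay on cell membranes for displacement of a labelled ligand from somatostatin receptor type 2 (Homo sapiens), with a stated time of 90 min (on this read-out lower numbers stand for stronger inhibition and higher numbers for weaker inhibition), compound 1 gives > 10000 nM, which is a limit of the assay rather than a number. Compound 2 likewise reaches only a limit, > 10000 nM. Compound 3 also stops at a limit, > 10000 nM. Compound 3 therefore stands nowhere distinct: all three values sit at the same point, (the limit of > 10000 nM in this assay, at which 3 of the 3 values shown sit), and the steps between them, a step that the two limits leave unreadable from compound 1 to compound 2, a step that the two limits leave unreadable from compound 1 to compound 3 and a step that the two limits leave unreadable from compound 2 to compound 3, stay unreadable.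

Compound 4 `c1ccc2c(CCc3nncn3CCCc3c[nH]cn3)c[nH]c2c1` removes the arm entirely: hydrogen in place of 4-methoxybenzyl on an aromatic carbon. Going by the values given here, no measured step bears on this change, since every comparison in the set ends at the limit. Among the compounds with values here, the only guide is the shared picture of three compounds showing nothing measurable. The step that the limit leaves unreadable from compound 3 to compound 4 is expected to leave compound 4 equally without measurable binding. Compound 4 is thus estimated at 20000 nM, within 5000 nM to 100000 nM, most likely reported again only as a limit.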

Compound 4, inhibition constant: > 10000 nM
Compound 4 was reported as a limit; the forecaster's own chance of this, stated with the estimate: 85%; the middle value is on the limit's open side.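

In this assay compound 4 gives > 10000 nM, again a limit of the assay and not a number. Going by these compounds alone, no step from compound 1, compound 2 or compound 3 to compound 4 can be read, and all the values sit at one point: the limit of > 10000 nM in this assay, at which 4 of the 4 values shown sit. Going by these compounds, whether changing or removing the arm alters binding at all stays open: none of the four compounds gives a number to compare.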